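From Methoxyphenyl to Dichlorophenyl: What to Expect

The source may hold more compounds than are shown below. What is called first, only, known or untested is meant among the compounds shown, and "the series" means these compounds.

Of the compounds shown here, three on a shared core have been tested in an assay on CHO cells for displacement of a labelled ligand from adenosine receptor A2b (Homo sapiens), read by scintillation counting, with a stated time of 75 min; a lower number here means a stronger inhibitor, a higher number a weaker inhibitor. Compound 1 `Cc1sc2nc(NC(=O)CCCc3ccccc3)sc(=O)c2c1C` gives only a limit, > 1000 nM, in this assay. Compound 3 `O=C(CCCc1ccccc1)Nc1nc2ccc(Br)cc2c(=O)s1` likewise reaches only the limit > 1000 nM in this assay. Compound 2 `COc1cccc(/C=C/CC(=O)Nc2nc3ccccc3c(=O)s2)c1` also returns a limit rather than a number, >= 1000 nM in this assay. Since every value shown sits at a limit (the limit of > 1000 nM in this assay, at which 2 of the 3 values shown sit, and (the limit of >= 1000 nM in this assay, at which 1 of the 3 values shown sits)), compound 2 cannot be ranked against the other two, and none of them can be called stronger or weaker.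

Compound 4 `O=C(C/C=C/c1ccc(Cl)c(Cl)c1)Nc1nc2ccccc2c(=O)s1` has not yet been measured. It differs from compound 2 in one place: 3,4-dichlorophenyl in place of 3-methoxyphenyl on a double-bonded chain carbon bound to a double-bonded chain carbon. For the measured compounds named here, no measured pair differing in one place exists here, so no direction can be read from the data. The expected step is a step that the limit leaves unreadable from compound 2 to compound 4, nothing beyond the usual scatter, with a limit again the most likely outcome. For compound 4 the estimated value in this assay is 1500 nM, within a range from 300 nM to 10000 nM.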

Compound 4, inhibition constant: > 1000 nM
Compound 4: no number, only a limit; the forecaster's own chance of this, stated with the estimate: 70%; the middle value lies beyond the limit too.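

In this assay compound 4 gives > 1000 nM, a limit and not a number. For the compounds shown here, compound 2 also gives only a limit, so no step between compound 2 and compound 4 can be read. The compounds shown leave open whether 3,4-dichlorophenyl or 3-methoxyphenyl gives the stronger inhibitor.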